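Difluorophenyl swap from compound 3 to compound 4

The compounds below may be only part of what the source reports. "The series", "measured", "known", "first", "only" and "open" are said of these compounds alone.

Of the compounds shown here, three have been measured in a functional assay on HT-29 cells (Homo sapiens) for inhibition, read by MTT assay; on this read-out lower numbers stand for stronger inhibition and higher numbers for weaker inhibition. Compound 1 `CCNC(=O)N1CCC(Oc2cc3nccc(Oc4ccc(NC(=O)NN5C(=O)CSC5c5ccc(F)cc5)cc4)c3cc2OC)CC1` gives 2250 nM, compound 2 `COc1cc2c(Oc3ccc(NC(=O)NN4C(=O)CSC4c4ccc(F)cc4)cc3)ccnc2cc1OC1CCN(C(=O)NC(C)C)CC1` gives 860 nM, and compound 3 `COc1cc2c(Oc3ccc(NC(=O)NN4C(=O)CSC4c4cccc(F)c4F)cc3)ccnc2cc1OC1CCN(C(=O)NC(C)C)CC1` gives 790 nM. Compound 3 thus stands within the scatter of compound 2 and beyond the scatter from compound 1.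

The next structure is compound 4 `COc1cc2c(Oc3ccc(NC(=O)NN4C(=O)CSC4c4ccc(F)cc4F)cc3)ccnc2cc1OC1CCN(C(=O)NC(C)C)CC1`, which carries 2,4-difluorophenyl in place of 2,3-difluorophenyl on a saturated ring carbon of a five-membered non-aromatic ring with 1 nitrogen and 1 sulfur (2,4-difluorophenyl in place of 2,3-difluorophenyl on a saturated ring carbon).

Two measured steps are available. Methyl in place of hydrogen on a saturated chain carbon gave a 2.6-fold lower number from compound 1 to compound 2 (0.42 log units; beyond the scatter), a modest step, but it concerns a different part of the molecule and bears little on this change. The closer precedent is 2,3-difluorophenyl in place of 4-fluorophenyl on the same ring carbon, which gave a 1.1-fold lower number from compound 2 to compound 3 (0.04 log units; within the scatter), within the scatter. Among the compounds with values here, no measured compound carries the 2,4-difluorophenyl group, so the expectation rests on that single step.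

No step beyond the scatter is expected in this assay. The estimate amounts to a 1.0-fold higher number from compound 3 to compound 4 (0.01 log units; within the scatter). For compound 4 the estimated value is 800 nM, with an expected range of 400 nM to 1600 nM.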

Compound 4, half-maximal inhibitory concentration: 950 nM
For compound 4 the middle estimate is 1.2-fold (0.07 log units) below the measured one; the range from low to high includes it.
By their numbers in this assay, from the lowest: compounds 3, 2 and 4 (each within the scatter of the next); then compound 1.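

Within this assay, moving one fluoro around the phenyl ring on the saturated ring carbon, next to the ring nitrogen and the ring sulfur, gives a 1.2-fold higher number from compound 3 to compound 4 (0.08 log units; within the scatter), so the 2,3-difluorophenyl and 2,4-difluorophenyl isomers cannot be told apart on this read-out. Adding a fluoro to the 4-fluorophenyl group of compound 2 gives a 1.1-fold higher number from compound 2 to compound 4 (0.04 log units; within the scatter), which matches the earlier 1.1-fold lower number from compound 2 to compound 3 (0.04 log units; within the scatter) and places all three fluorinated phenyl variants with the isopropyl side chain within the scatter of one another. No available evidence bears on why these three variants read alike.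

On these data alone, all three variants keep a fluorinated phenyl ring on this carbon, so it remains open whether an unsubstituted phenyl, a chlorophenyl, a methoxyphenyl or a pyridyl group would produce a step beyond the scatter. Within the data shown here, it is also open whether this flat response holds with the ethyl side chain of compound 1, since the only step beyond the scatter so far is a 2.6-fold lower number from compound 1 to compound 2 (0.42 log units; beyond the scatter), at a different place in the molecule.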